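Methyl on the Fused Core: Compound 2 to Compound 4

The compounds below may be only part of what the source reports. "The series", "measured", "known", "first", "only" and "open" are said of these compounds alone.

Measured compounds:
compound 1, `Cc1cc(-c2nc3n(c2/C=N/NC(=N)N)CCS3)c(C)s1`, 38000 nM
compound 2, `N=C(N)N/N=C/c1c(-c2cccs2)nc2sccn12`, 21900 nM
compound 3, `N=C(N)N/N=C/c1c(-c2ccsc2)nc2sccn12`, 29500 nM

Of the compounds shown here, three have been tested in a functional assay on cells (Cancer cell lines, Homo sapiens) for inhibition; a higher number here means a weaker inhibitor of growth, a lower number a stronger inhibitor of growth. Compound 2 gives the smallest of the three numbers, but its gaps to compound 3 and to compound 1 are both within the scatter, so the three cannot be told apart on these data. Within the data shown here, the one single-point step that has been measured, a 1.3-fold higher number from compound 2 to compound 3 (0.13 log units; within the scatter), moves the thiophene attachment and stays within the scatter.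

Compound 4, `Cc1cn2c(/C=N/NC(=N)N)c(-c3cccs3)nc2s1`, has not yet been measured. It differs from compound 2 in one place: methyl in place of hydrogen on an aromatic carbon.

Among the measured compounds shown here, no measured step adds a methyl to the shared core, so nothing bears directly on this change. For the measured compounds named here, the only comparison available, between compound 2 and compound 3, shows that a change on the aromatic substituent left the number within the scatter. With nothing pointing either way, the step of a 1.0-fold higher number from compound 2 to compound 4 (0.00 log units; within the scatter) is expected to stay within the scatter. Compound 4 is therefore estimated at 22000 nM, with a range from 8000 nM to 60000 nM.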

Compound 4, concentration for total growth inhibition: 14100 nM
The estimate for compound 4 lay 1.6-fold (0.19 log units) above the measured number; the range from low to high includes it.
By their numbers in this assay, from the lowest: compounds 4, 2, 3 and 1 (each within the scatter of the next, the first and the last beyond it).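

In this assay, among these compounds, methyl in place of hydrogen on an aromatic carbon, next to the ring sulfur, gives a 1.6-fold lower number from compound 2 to compound 4 (0.19 log units; within the scatter), the first measured step on the shared core rather than on the aromatic substituent. This position therefore takes a methyl without a number that can be told apart from that of compound 2, so the position has now been probed directly, though only with this one small group. Nothing measured alongside these numbers accounts for this result.

From the compounds shown here alone, whether another group at this position, such as an ethyl chain, a chlorine atom or a carboxylic acid, would move the number beyond the scatter remains open. Also open, going by these compounds, is whether the methyl would behave the same way with the thiophen-3-yl group of compound 3 in place of thiophen-2-yl.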